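The source may hold more compounds than are shown below. What is called first, only, known or untested is meant among the compounds shown, and "the series" means these compounds.

Working notes on the series. Going by the values given here, compound 3 `COc1ccc2[nH]c(-c3ccccc3)c(/C=C(\C#N)S(=O)(=O)c3ccccc3)c2c1` gives 7100 nM in a functional assay on SK-OV-3 cells (Homo sapiens) for inhibition, read by sulforhodamine B assay, with a stated time of 48 h (on this read-out higher numbers stand for weaker inhibition of growth and lower numbers for stronger inhibition of growth), and stands second highest of the three numbers measured so far. Compound 2 `O=C(/C(=C\c1c(-c2ccccc2)[nH]c2ccccc12)S(=O)(=O)c1ccccc1)c1ccccc1` gives 7600 nM in this assay, which lies within the scatter of compound 3. Compound 1 `CC(=O)/C(=C\c1c(-c2ccccc2)[nH]c2ccccc12)S(=O)(=O)c1ccccc1` gives 2900 nM in this assay, a lower number beyond the scatter. Among the compounds with values here, the only measured step, a 2.6-fold higher number from compound 1 to compound 2 (0.42 log units; beyond the scatter), concerns the carbonyl substituent and does not bear on the change considered here. Compound 4 `N#C/C(=C\c1c(-c2ccccc2)[nH]c2ccccc12)S(=O)(=O)c1ccccc1` differs from compound 3 by hydrogen in place of methoxy on an aromatic carbon. Within the data shown here, no measured pair shows this change, so no step beyond the scatter is expected in this assay. Compound 4 is therefore estimated at 6000 nM, with a range of 2500 nM to 15000 nM. This corresponds to an expected step of a 1.2-fold lower number from compound 3 to compound 4 (0.07 log units; within the scatter).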

Compound 4, concentration for 50% growth inhibition: 6800 nM
The estimate for compound 4 lay 1.1-fold (0.05 log units) below the measured number; the range from low to high includes it.
By their numbers in this assay, from the lowest: compound 1; then compounds 4, 3 and 2 (each within the scatter of the next).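

Hydrogen in place of methoxy on this aromatic carbon gives a 1.0-fold lower number from compound 3 to compound 4 (0.02 log units; within the scatter) in this assay, so this pair shows that the methoxy can be removed with no change beyond the scatter. Compound 4 also allows a direct comparison on the chain carbon: cyano in place of benzoyl gives a 1.1-fold lower number from compound 2 to compound 4 (0.05 log units; within the scatter), while cyano in place of acetyl gives a 2.3-fold higher number from compound 1 to compound 4 (0.37 log units; beyond the scatter), leaving compound 1 alone apart from compounds 2 and 4. No evidence at hand accounts for these results.

On these data alone, whether an amine, a hydroxyl or a longer alkoxy chain on this aromatic carbon would match hydrogen and methoxy remains open. So does whether the methoxy step would hold with acetyl in place of cyano.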